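The compounds below may be only part of what the source reports. "The series", "measured", "known", "first", "only" and "open" are said of these compounds alone.

Measured so far:
Compound 1 `CCCCN(C)c1nc(C(F)(F)F)ccc1CNC(=O)C(C)c1ccc(NS(C)(=O)=O)c(F)c1`: 0.8 nM
Compound 2 `CC(C(=O)NCc1ccc(C(F)(F)F)nc1N1CC=CCC1)c1ccc(NS(C)(=O)=O)c(F)c1`: 0.3 nM

Both were tested in a functional assay on CHO-K1 cells for antagonist activity at transient receptor potential cation channel subfamily V member 1 (Homo sapiens), read by FLIPR; a higher number here means a weaker inhibitor, a lower number a stronger inhibitor. Compound 2 gives the lower number of the two, and the step of a 2.7-fold lower number from compound 1 to compound 2 (0.43 log units; beyond the scatter) places it beyond the scatter, so it stands as the stronger inhibitor of the pair. Compound 3 `CCCCOC1CCN(c2nc(C(F)(F)F)ccc2CNC(=O)C(C)c2ccc(NS(C)(=O)=O)c(F)c2)CC1` keeps the shared core and alters only the group on the aromatic carbon next to the ring nitrogen: a group of 11 heavy atoms (9 carbon, 1 nitrogen, 1 oxygen; one six-membered non-aromatic ring with 1 hetero atom) in place of a group of 6 heavy atoms (5 carbon, 1 nitrogen; one six-membered non-aromatic ring with 1 hetero atom), on an aromatic carbon. Among the measured compounds shown here, the one measured step at this position, a 2.7-fold lower number from compound 1 to compound 2 (0.43 log units; beyond the scatter), shows that a ring in place of a chain there brought a modest gain. For the measured compounds named here, the group entering compound 3 is considerably larger, and no measured compound shows how such a group is received here. A small rise in the number is therefore expected, near the scatter, as a 2.7-fold higher number from compound 2 to compound 3 (0.43 log units; beyond the scatter). The estimate for compound 3 in this assay is 0.8 nM, with a range from 0.2 nM to 4 nM.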

Compound 3, inhibition constant: 3.5 nM
Compound 3: the middle estimate sits 4.4-fold (0.64 log units) below what was measured, within the range that was stated.
By their numbers in this assay, from the lowest: compound 2; then compound 1; then compound 3.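

In this assay, the larger group of 11 heavy atoms on the aromatic carbon next to the ring nitrogen gives a 12-fold higher number from compound 2 to compound 3 (1.07 log units; beyond the scatter), so this position does not receive every six-membered non-aromatic ring equally well. A ring alone is therefore not enough for a low number here: the same group also compares poorly with the ringless group of compound 1, with a 4.4-fold higher number from compound 1 to compound 3 (0.64 log units; beyond the scatter). Nothing available gives a reason for this loss.

The group entering compound 3 differs from the one leaving compound 2 in size, in its oxygen and in lacking the double bond, and these compounds leave open which of these differences matters. A methoxy group in place of the butoxy chain would test whether the number depends on the length of that chain.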